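Swapping the Thiophene Group on Compound 2

The source may hold more compounds than are shown below. What is called first, only, known or untested is meant among the compounds shown, and "the series" means these compounds.

In a functional assay on B16 cells (Mus musculus) for inhibition (on this read-out higher numbers stand for weaker inhibition and lower numbers for stronger inhibition), compound 1 (`COC(=O)Nc1nc2c(C)cc(C(=O)c3cccs3)cc2[nH]1`) gives 60 nM, while compound 2 (`COC(=O)Nc1nc2cc(C(=O)c3ccc(C)s3)ccc2[nH]1`) gives 10000 nM, the higher of the two numbers and beyond the scatter of compound 1. Compound 3 (`COC(=O)Nc1nc2cc(C(=O)c3cc(CO)cs3)ccc2[nH]1`) carries 4-(hydroxymethyl)thiophen-2-yl in place of 5-methylthiophen-2-yl on a carbonyl carbon. Within the data shown here, no measured pair shows this change on its own, so the forecast is uncertain. A moderate step towards stronger inhibition is expected, estimated as a 3.3-fold lower number from compound 2 to compound 3 (0.52 log units; beyond the scatter). For compound 3 the estimated value in this assay is 3000 nM, with an expected range of 500 nM to 15000 nM.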

Compound 3, half-maximal inhibitory concentration: 1800 nM
For compound 3 the middle estimate is 1.7-fold (0.22 log units) above the measured one; low and high end bracket the measured number.
By their numbers in this assay, from the lowest: compound 1; then compound 3; then compound 2.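

In this assay, the group on the carbonyl carbon now shows that it can shift the read-out: 4-(hydroxymethyl)thiophen-2-yl in place of 5-methylthiophen-2-yl gives a 5.6-fold lower number from compound 2 to compound 3 (0.74 log units; beyond the scatter) and so a modest gain in inhibition. Nothing available explains this step. The compounds shown leave open whether the hydroxymethyl group or its place on the thiophene accounts for the step, since the two change together. 4-Methylthiophen-2-yl or 5-(hydroxymethyl)thiophen-2-yl would separate them, and an aminomethyl or carboxylic acid group there remains an open case.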